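Two Chlorines in Place of One Fluorine

The source may hold more compounds than are shown below. What is called first, only, known or untested is meant among the compounds shown, and "the series" means these compounds.

Compound 1 `O=c1ccc(-c2ccc3cn[nH]c3c2)cn1Cc1cccc(Cl)c1` gives 40 nM in an assay for inhibition of MAP kinase-interacting serine/threonine-protein kinase 2 (Homo sapiens), read by luminescence and ADP-Glo, with a stated time of 2 h; a lower number here means a stronger inhibitor, a higher number a weaker inhibitor.
Compound 2 `O=c1ccc(-c2ccc3cn[nH]c3c2)cn1Cc1ccccc1Cl` gives 78 nM in this assay.
Compound 3 `O=c1ccc(-c2ccc3cn[nH]c3c2)cn1Cc1ccccc1F` gives 37 nM in this assay.

Compound 3 has the lowest of the three numbers, but its nearest neighbour is compound 1, and the step of a 1.1-fold lower number from compound 1 to compound 3 (0.03 log units; within the scatter) is within the scatter, so the two cannot be ordered. Among the compounds with values here, only the step of a 2.1-fold lower number from compound 2 to compound 3 (0.32 log units; beyond the scatter) stands beyond it, and that one is modest. The step of a 2.0-fold higher number from compound 1 to compound 2 (0.29 log units; within the scatter) is within the scatter as well.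

Compound 4 `O=c1ccc(-c2ccc3cn[nH]c3c2)cn1Cc1ccc(Cl)c(Cl)c1` differs from compound 3 in one place: 3,4-dichlorophenyl in place of 2-fluorophenyl on a saturated chain carbon bound to an aromatic nitrogen. Two of the measured steps bear on this. The step of a 1.1-fold lower number from compound 1 to compound 3 (0.03 log units; within the scatter) shows that a 3-chlorophenyl and a 2-fluorophenyl on that saturated chain carbon give numbers within the scatter of each other, and the step of a 2.1-fold lower number from compound 2 to compound 3 (0.32 log units; beyond the scatter) shows that a chloro in place of a fluoro on an aromatic carbon shifts the number only modestly. Nothing measured covers a second chlorine on the 3,4-dichlorophenyl. Compound 4 is therefore expected to stay close to compound 3, with the step of a 1.2-fold higher number from compound 3 to compound 4 (0.09 log units; within the scatter) lying within the scatter. The estimate for compound 4 in this assay is 45 nM, between 15 nM and 140 nM.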

Compound 4, half-maximal inhibitory concentration: 97 nM
Estimate against measurement, compound 4: 2.2-fold (0.33 log units) below; low and high end bracket the measured number.
By their numbers in this assay, from the lowest: compounds 3, 1, 2 and 4 (each within the scatter of the next, the first and the last beyond it).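

Adding a chloro to an aromatic carbon of the 3-chlorophenyl gives a 2.4-fold higher number from compound 1 to compound 4 (0.38 log units; beyond the scatter), the first measured sign that a second chlorine on this ring moves the number, if only modestly, towards a weaker inhibitor. The 3,4-dichlorophenyl likewise stands apart from the 2-fluorophenyl, with a 2.6-fold higher number from compound 3 to compound 4 (0.42 log units; beyond the scatter), but not from the 2-chlorophenyl, with a 1.2-fold higher number from compound 2 to compound 4 (0.09 log units; within the scatter), so those two groups cannot be ordered at this position. Nothing available explains the shift produced by the second chlorine.

The compounds leave open whether this shift is particular to chlorine or would follow from another second substituent, as only chloro and fluoro appear on the ring. They also leave open how a methoxy group, an amine or a carboxylic acid on that ring would read in this assay.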